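Chloro to methoxy on the shared core: working notes

The source may hold more compounds than are shown below. What is called first, only, known or untested is meant among the compounds shown, and "the series" means these compounds.

- compound 1 `Cc1ccccc1-c1cc(C(=O)N2CCC3(CC2)CC(=O)c2nn(C(C)(C)C)cc2O3)c2ccccc2n1`: > 10000 nM, a limit
- compound 2 `CC(C)(C)n1cc2c(n1)C(=O)CC1(CCN(C(=O)c3cc(Cl)nc4ccccc34)CC1)O2`: 9220 nM

Among the compounds with values here, in a functional assay on MDA-MB-231 cells (Homo sapiens) for inhibition, read by MTT assay, with a stated time of 72 h (a lower number here means a stronger inhibitor, a higher number a weaker inhibitor), compound 2 gives 9220 nM, the only true number so far. Compound 1 gives > 10000 nM, which is a limit. Within the data shown here, the one measured step, an at least 1.0-fold lower number from compound 1 to compound 2 (0.03 log units; that floor lies within the scatter), put chloro in place of 2-methylphenyl on an aromatic carbon, and it gives no usable size. Compound 3 `COc1cc(C(=O)N2CCC3(CC2)CC(=O)c2nn(C(C)(C)C)cc2O3)c2ccccc2n1` carries methoxy in place of chloro on an aromatic carbon. With so little to go on, no step beyond the scatter is expected in this assay. The expected step is a 1.0-fold lower number from compound 2 to compound 3 (0.01 log units; within the scatter). For compound 3 the estimate is 9000 nM, with an expected range of 4000 nM to 20000 nM.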

Compound 3, half-maximal inhibitory concentration: > 10000 nM
Compound 3 was reported as a limit; the forecaster's own chance of this, stated with the estimate: 45%; at least 1.1-fold (0.04 log units) between middle value and limit.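

In this assay, on these data alone, methoxy on the aromatic carbon next to the ring nitrogen gives an at least 1.0-fold higher number from compound 2 to compound 3 (0.03 log units; that floor lies within the scatter), so methoxy offers no lower number than chloro and the true size of the step stays open. Compound 3 now stands at a limit alongside compound 1, so the step between those two cannot be read, and neither compound gives a true number: the limit of > 10000 nM in this assay, at which 2 of the 3 values shown sit.

As far as these compounds go, whether an amine or a carboxylic acid on this carbon would give a clearly lower number remains open. So does whether any group here can bring the series well clear of that limit.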